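This account rests on a few compounds, and the source may have more. Where it says the series, first, only, none or still open, it means among the compounds named here.

Measured in an ADME assay on HEK293 cells (Homo sapiens) for cytotoxicity, with a stated time of 72 h; on this read-out higher numbers stand for an effect only at larger amounts of compound and lower numbers for an effect already at smaller amounts:
- Compound 1 `C=C[C@@](C)(/C=C/c1ccc(OCc2ccccc2)cc1)CCC=C(C)C`: > 36600 nM
- Compound 2 `C=C[C@@](C)(/C=C/c1ccc(O)c(CO)c1)CCC=C(C)C`: > 36600 nM
- Compound 3 `COc1ccc(/C=C/[C@@](C)(/C=C/c2ccc(O)c(C=O)c2)CCC=C(C)C)cc1`: 2270 nM

Among the compounds with values here, compound 3, at 2270 nM, is the only compound here with a true number. Compound 1 gives only a limit of the assay, > 36600 nM. Compound 2 likewise gives only a limit, > 36600 nM.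

Compound 4 `COc1ccc(/C=C/[C@@](C)(/C=C/c2ccc(O)c(/C=C/C(=O)OC(C)(C)C)c2)CCC=C(C)C)cc1` keeps the rest of compound 3 but carries 2-(tert-butoxycarbonyl)ethenyl in place of formyl on an aromatic carbon, ortho to a hydroxy group (2-(tert-butoxycarbonyl)ethenyl in place of formyl on an aromatic carbon).

Within the data shown here, no two measured compounds differ in one place only, so this change has no measured precedent, and the forecast is uncertain. Compound 3, at 2270 nM, is the single numerical anchor. The expected change is a 2.6-fold higher number from compound 3 to compound 4 (0.42 log units; beyond the scatter), a moderate rise in this assay. Compound 4 might also end up at the limit of > 36600 nM in this assay, at which 2 of the 3 values shown sit. The estimated value for compound 4 is 6000 nM, with an expected range from 1500 nM to 30000 nM.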

Compound 4, half-maximal effective concentration: > 36600 nM
Compound 4 ended at the assay's limit; the forecaster's own chance of this, stated with the estimate: 30%; at least 6.1-fold (0.78 log units) between middle value and limit.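

Putting 2-(tert-butoxycarbonyl)ethenyl in place of formyl on this aromatic carbon, ortho to a hydroxy group, gives an at least 16-fold higher number from compound 3 to compound 4 (1.20 log units; beyond the scatter), so in this assay the effect depends on what this position carries. Compound 4 gives > 36600 nM, which is a limit of the assay and not a number. Compound 3 therefore remains the only compound here with a true number: the limit of > 36600 nM in this assay, at which 3 of the 4 values shown sit.

The compounds shown cannot tell whether the loss of formyl or the arrival of the new group drives this step, and the limit leaves its full size unknown. From the compounds shown here alone, it also remains open whether a nitrile, or a carboxylic acid in place of the tert-butyl ester, would give a true number at this position.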